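The source may hold more compounds than are shown below. What is called first, only, known or untested is meant among the compounds shown, and "the series" means these compounds.

Measured so far in a functional assay on A549 cells (Homo sapiens) for inhibition, read by MTT assay, with a stated time of 72 h; on this read-out lower numbers stand for stronger inhibition of growth and higher numbers for weaker inhibition of growth
- compound 1 `COC(=O)/C=C/C1=CC[C@H]2C(C)(C)CCC[C@]2(C)[C@H]1C=O` gives 21000 nM
- compound 2 `CCOC(=O)/C=C/C1=CC[C@H]2C(C)(C)CCC[C@]2(C)[C@H]1C=O` gives 25000 nM
- compound 3 `COC(=O)/C=C/C=C/C1=CC[C@H]2C(C)(C)CCC[C@]2(C)[C@H]1C=O` gives 29000 nM

Compound 3 lies within the scatter of both other compounds (a 1.4-fold higher number from compound 1 to compound 3 (0.14 log units; within the scatter); a 1.2-fold higher number from compound 2 to compound 3 (0.06 log units; within the scatter)). Both steps change the group at the same place, and the ester change elsewhere is also small (a 1.2-fold higher number from compound 1 to compound 2 (0.08 log units; within the scatter)). Compound 4 `CC1(C)CCC[C@]2(C)[C@@H](C=O)C(/C=C/C#N)=CC[C@@H]12` has cyano in place of 2-(methoxycarbonyl)ethenyl on a double-bonded chain carbon bound to a double-bonded chain carbon. Among the compounds with values here, no measured compound carries cyano, so the evidence is indirect. In this assay no step beyond the scatter is expected (a 1.2-fold lower number from compound 3 to compound 4 (0.06 log units; within the scatter)). The estimate for compound 4 is 25000 nM, with an expected range of 12000 nM to 50000 nM.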

Compound 4, concentration for 50% growth inhibition: 27000 nM
Compound 4: middle estimate off by 1.1-fold (0.03 log units), on the low side; measured number inside the range.
By their numbers in this assay, from the lowest: compounds 1, 2, 4 and 3 (each within the scatter of the next).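

In this assay the step to cyano stays within the scatter against each ester: a 1.1-fold lower number from compound 3 to compound 4 (0.03 log units; within the scatter), a 1.1-fold higher number from compound 2 to compound 4 (0.03 log units; within the scatter) and a 1.3-fold higher number from compound 1 to compound 4 (0.11 log units; within the scatter). At this place on the double-bonded chain carbon, then, an ester group is not needed to keep the number in this range, since a cyano group without any oxygen reads alike. Nothing measured here explains why these groups read alike. On these data alone, it remains open whether any group at this place can move the number beyond the scatter, such as an amine or a carboxylic acid.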